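A Nitro Swap on a Weakly Active Ester

A few compounds are considered here, and "the series" means these few. Any claim that something is new, unique, unknown or untested is made for them only; others in the source may bear on it.

Compound 1 (`COc1ccc(/C=C/C(=O)OC/C=C/c2ccc(OC)c(OC)c2)cc1`) reads > 100 ug/mL in a functional assay on CNE cells (Homo sapiens) for cytotoxicity, read by MTT assay, with a stated time of 72 h (a lower number here means a stronger inhibitor, a higher number a weaker inhibitor), and that is a limit, not a number. Compound 2 (`COCOc1ccc(/C=C/C(=O)OC/C=C/c2ccccc2)cc1OCOC`) reads > 100 ug/mL and that is also a limit. Compound 3 (`COc1ccc(/C=C/COC(=O)/C=C/c2cc(OC)c(OC)c(OC)c2)cc1OC`) reads > 100 ug/mL and that is a limit too. Among the measured compounds shown here, the picture so far is thus the limit of > 100 ug/mL in this assay, at which 3 of the 3 values shown sit, with no measured step to scale the next change. Compound 4 (`COc1ccc(/C=C/COC(=O)/C=C/c2ccc([N+](=O)[O-])cc2)cc1OC`) differs from compound 1 by nitro in place of methoxy on an aromatic carbon, para to a large group (nitro in place of methoxy on an aromatic carbon). In this assay the expected change is an at least 1.4-fold lower number from compound 1 to compound 4 (0.15 log units; that floor lies within the scatter) as a modest move towards stronger inhibition. The estimated value for compound 4 is 70 ug/mL within an expected range of 20 ug/mL to 180 ug/mL as a rough guess.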

Compound 4, half-maximal inhibitory concentration: > 100 ug/mL
Compound 4 gave a limit, no number; the forecaster's own chance of this, stated with the estimate: 55%; middle value at least 1.4-fold (0.15 log units) from the limit.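

Among the compounds shown here, compound 1 and compound 4 both end at a limit, not a number, so no step between them can be read: the limit of > 100 ug/mL in this assay, at which 4 of the 4 values shown sit. The compounds shown leave open whether swapping methoxy for nitro changes activity at all, and by how much.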